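A few compounds are considered here, and "the series" means these few. Any claim that something is new, unique, unknown or untested is made for them only; others in the source may bear on it.

Working notes on the series:

- compound 1 `O=[N+]([O-])c1ccc(COc2ccc(Nc3ncnc4cc5c(cc34)OCCOCCO5)cc2)cc1`: 55200 nM
- compound 2 `FC(F)(F)c1ccc(COc2cccc(Nc3ncnc4cc5c(cc34)OCCOCCOCCO5)c2)cc1`: 20000 nM

In a functional assay on SH-SY5Y cells (Homo sapiens) for antiproliferative activity, read by MTT assay, with a stated time of 72 h (on this read-out higher numbers stand for weaker inhibition and lower numbers for stronger inhibition), compound 1 gives 55200 nM, the higher of the two numbers, and compound 2 gives 20000 nM, lower by more than the usual scatter. Compound 1 is therefore the weaker inhibitor of this pair.

Compound 3 `FC(F)(F)c1ccc(COc2ccc(Nc3ncnc4cc5c(cc34)OCCOCCO5)cc2)cc1` keeps the core of compound 1 and changes one group: trifluoromethyl in place of nitro on an aromatic carbon. Trifluoromethyl stands in place of nitro on an aromatic carbon, para to a large group.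

Going by the values given here, no measured pair isolates this change. Among the compounds with values here, the only guide is compound 2 at 20000 nM, which also carries trifluoromethyl but differs from compound 1 in other places too. A small step toward a lower number is expected in this assay, probably not clearly beyond the scatter. The estimated change is a 1.7-fold lower number from compound 1 to compound 3 (0.22 log units; within the scatter). For compound 3 the estimated value is 33000 nM, with an expected range of 13000 nM to 75000 nM.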

Compound 3, half-maximal inhibitory concentration: 30400 nM
Beside the measured number, compound 3's estimate is 1.1-fold (0.04 log units) above it; low and high end bracket the measured number.
By their numbers in this assay, from the lowest: compounds 2, 3 and 1 (each within the scatter of the next, the first and the last beyond it).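

Going by these compounds alone, the pair of compound 1 and compound 3 is the first to isolate a single place: in this assay, the change from 4-nitrobenzyl to 4-(trifluoromethyl)benzyl on the shared core gives a 1.8-fold lower number from compound 1 to compound 3 (0.26 log units; within the scatter) and nothing more. On an aromatic carbon, para to a large group, nitro and trifluoromethyl therefore cannot be told apart on this read-out, so this position tolerates either group without a resolvable difference. No measurement of any property of these compounds bears on this result.

On these data alone, whether an amine, a carboxylic acid or a longer chain at this carbon would give a number clearly apart from these two remains open. So does the outcome of the same trifluoromethyl for nitro change on a different core.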